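Aryl versus cycloalkyl on the amine: compound 3 to compound 4

The source may report more compounds than this note shows. Statements on the series, on what has been measured and on what is new or still open speak of the compounds shown alone.

Measured in a functional assay on HeLa cells (Homo sapiens) for inhibition, read by sulforhodamine B assay; a higher number here means a weaker inhibitor, a lower number a stronger inhibitor:
- compound 1 `O=C1C=C(NC2CCCCC2)C(=O)c2c1nc1n2[C@H]2OC[C@@H](O)[C@H]2OC1`: > 16000 nM
- compound 2 `O=C1C=C(Nc2cccc(F)c2)C(=O)c2c1nc1n2[C@H]2OC[C@@H](O)[C@H]2OC1`: 6440 nM
- compound 3 `O=C1C=C(NC2CCCC2)C(=O)c2c1nc1n2[C@H]2OC[C@@H](O)[C@H]2OC1`: > 16000 nM

Compound 3 stands at > 16000 nM, which is a limit and not a number. It shares this position with compound 1, as the limit of > 16000 nM in this assay, at which 2 of the 3 values shown sit, records. Compound 2 is the only one of the three with a numerical value.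

Compound 4 `CCOc1ccc(NC2=CC(=O)c3nc4n(c3C2=O)[C@H]2OC[C@@H](O)[C@H]2OC4)cc1` is the next compound to consider. The change is 4-ethoxyphenyl in place of cyclopentyl on an amine nitrogen, with 4-ethoxyphenyl in place of cyclopentyl on an amine nitrogen.

Among the measured compounds shown here, two measured steps bear on this exchange of a cycloalkyl group for an aryl group. One is an at least 2.4-fold lower number from compound 1 to compound 2 (0.39 log units; beyond the scatter). The other, running in the opposite direction, is an at least 2.4-fold higher number from compound 2 to compound 3 (0.39 log units; beyond the scatter). Both lie beyond the scatter, and both favour the aryl compound. They rest on a single aryl example, compound 2 at 6440 nM, and 4-ethoxyphenyl has not been tested.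

A modest move to a lower number is therefore expected, and a reading at the limit remains possible. The expected change in this assay is an at least 2.6-fold lower number from compound 3 to compound 4 (0.42 log units; beyond the scatter). For compound 4 the estimated value is 6000 nM, with an expected range of 2000 nM to 16000 nM.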

Compound 4, half-maximal inhibitory concentration: 3110 nM
The estimate for compound 4 lay 1.9-fold (0.29 log units) above the measured number; low and high end bracket the measured number.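

In this assay the change to 4-ethoxyphenyl on the amine nitrogen gives an at least 5.1-fold lower number from compound 3 to compound 4 (0.71 log units; beyond the scatter) and also an at least 5.1-fold lower number from compound 1 to compound 4 (0.71 log units; beyond the scatter) in the same direction as the earlier 3-fluorophenyl steps, so the preference for aryl over cycloalkyl at this position no longer rests on a single aryl example. The aryl groups also separate from each other: 4-ethoxyphenyl in place of 3-fluorophenyl gives a 2.1-fold lower number from compound 2 to compound 4 (0.32 log units; beyond the scatter) as a modest step, so the choice of aryl group moves the number as well as the switch from cycloalkyl to aryl. Going by these compounds, compound 1 and compound 3 remain limits and not numbers, so the steps from them give only a smallest size and the full gain from cycloalkyl to aryl stays unknown: the limit of > 16000 nM in this assay, at which 2 of the 4 values shown sit.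

Compound 2 and compound 4 differ in both the group carried on the aromatic ring and where it sits, so the two contributions cannot be separated from these compounds. Open questions are how an unsubstituted phenyl, a 3-ethoxyphenyl or a 4-fluorophenyl would read on the same amine nitrogen, and whether a benzyl or a pyridyl would keep the gain.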